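The source may report more compounds than this note shows. Statements on the series, on what has been measured and on what is new or still open speak of the compounds shown alone.

Compound 1 `CCOc1nc(N)nc2c1ncn2/C=C1/CC1(CO)CO` carries an ethoxy group on the shared core. In an ADME assay on BCBL1 cells (Homo sapiens) for cytotoxicity, with a stated time of 7 days (a higher number here means that more compound is tolerated, a lower number that less compound is tolerated), compound 1 gives > 20000 nM, which is a limit of the assay rather than a number. Compound 2 `Nc1nc(OCc2ccccc2)c2ncn(/C=C3/CC3(CO)CO)c2n1` also reaches only a limit in this assay, > 20000 nM. Compound 3 `Nc1nc(NC2CC2)c2ncn(/C=C3/CC3(CO)CO)c2n1` gives 71500 nM in this assay. The step that the two limits leave unreadable from compound 1 to compound 2, the step that the limit leaves unreadable from compound 1 to compound 3 and the step that the limit leaves unreadable from compound 2 to compound 3 all remain unreadable because of the limit of > 20000 nM in this assay, at which 2 of the 3 values shown sit. Compound 4 `Nc1nc(N2CCCC2)c2ncn(/C=C3/CC3(CO)CO)c2n1` differs from compound 1 by pyrrolidin-1-yl in place of ethoxy on an aromatic carbon. With no readable step among the measured compounds in this assay, no direction can be expected beyond the scatter. Compound 4 is therefore expected to sit around 50000 nM (from 20000 nM to 150000 nM), an expected step that the limit leaves unreadable from compound 1 to compound 4.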

Compound 4, half-maximal cytotoxic concentration: > 20000 nM
Compound 4: only a limit was reported; the forecaster's own chance of this, stated with the estimate: 55%; the middle value does not contradict the limit.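

Compound 4 adds no readable step against compound 1, compound 2 or compound 3 in this assay, because these comparisons rest on a limit: the limit of > 20000 nM in this assay, at which 3 of the 4 values shown sit. The compounds shown leave open how the ethoxy, benzyloxy, cyclopropylamino and pyrrolidin-1-yl groups rank against one another.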